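The compounds below may be only part of what the source reports. "The series", "measured", "known", "first", "only" and "open" are said of these compounds alone.

Measured so far:
- compound 1, `CN(C(=O)NC(=O)c1ccc(Cl)cc1Cl)c1nc(C(F)(F)F)c(C(=O)N/N=C/c2ccc(C(F)(F)F)cc2)s1`: 3.08 ug/mL
- compound 2, `CN(C(=O)NC(=O)c1c(F)cccc1F)c1nc(C(F)(F)F)c(C(=O)N/N=C/c2cccc(C(F)(F)F)c2)s1`: 25.9 ug/mL
- compound 3, `Cc1nc(N(C)C(=O)NC(=O)c2c(F)cccc2F)sc1C(=O)N/N=C/c1cccc(C(F)(F)F)c1`: 32.7 ug/mL

In a functional assay on BCG823 cells (Homo sapiens) for inhibition, read by MTT assay, with a stated time of 72 h (on this read-out lower numbers stand for stronger inhibition and higher numbers for weaker inhibition), compound 1 gives 3.08 ug/mL, the lowest number of the three; compound 2 and compound 3 both give higher numbers, beyond the usual scatter. Compound 1 and compound 2 differ in more than one place, and the difference between the two cores is not broken down here.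

Within the pair that shares a core, the change from compound 2 to compound 3 is methyl in place of trifluoromethyl on an aromatic carbon, and it made a 1.3-fold higher number from compound 2 to compound 3 (0.10 log units; within the scatter), a step within the scatter.

Compound 4, `Cc1nc(N(C)C(=O)NC(=O)c2ccc(Cl)cc2Cl)sc1C(=O)N/N=C/c1ccc(C(F)(F)F)cc1`, has not been measured. It differs from compound 1 by methyl in place of trifluoromethyl on an aromatic carbon, which is the same change as that between compound 2 and compound 3, at a place described in the same words.

For compound 4 the expected step in this assay is a 1.3-fold higher number from compound 1 to compound 4 (0.11 log units; within the scatter), resting on compound 2 and compound 3, where the same change gave a 1.3-fold higher number from compound 2 to compound 3 (0.10 log units; within the scatter). The estimate for compound 4 is therefore 4 ug/mL, with a range from 2 ug/mL to 9 ug/mL.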

Compound 4, half-maximal inhibitory concentration: 38 ug/mL
For compound 4 the middle estimate is 9.5-fold (0.98 log units) below the measured one; measured number above the stated range.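

In this assay, methyl in place of trifluoromethyl on an aromatic carbon does not carry over from one core to the other with the same size of step: the same change on two cores in this assay, a 1.3-fold higher number (0.10 log units; within the scatter) from compound 2 to compound 3 and a 12-fold higher number (1.09 log units; beyond the scatter) from compound 1 to compound 4, 9.8-fold (0.99 log units) apart, beyond the scatter of two such steps. On the core of compound 1 the change gave a 12-fold higher number from compound 1 to compound 4 (1.09 log units; beyond the scatter), so the small step on the other core is no guide to its size here. The two pairs differ from each other in more than one place, so these compounds do not show which of those differences makes the step depend on the core, and two pairs give no rule for any further core.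

Still open, going by these compounds, is how the change behaves across cores that differ in one place only, which would show where the dependence on the core arises. Also open, on these data alone, is whether another group on the aromatic carbon next to the ring nitrogen, such as an amine, a carboxylic acid or a longer chain, would give a number closer to that of compound 1 or of compound 4.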